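The compounds below may be only part of what the source reports. "The series", "measured", "known", "first", "only" and "open" are said of these compounds alone.

Compound 1 `COc1ccc2c(c1)C(C)=CC(C)(C)N2Cc1cn(Cc2cc3cc(OC)ccc3nc2Cl)nn1` gives 30900 nM
Compound 2 `CC1=CC(C)(C)N(Cc2cn(Cc3cc4cc(C)ccc4nc3Cl)nn2)c2ccccc21` gives 29400 nM

Both numbers come from a functional assay on A549 cells (Homo sapiens) for cytotoxicity, read by MTT assay, with a stated time of 48 h (on this read-out lower numbers stand for stronger inhibition and higher numbers for weaker inhibition), and lie within the usual scatter of each other. Compound 2 at 29400 nM therefore cannot be told apart from compound 1 on this evidence. The next molecule to be tested is compound 3 `COc1ccc2nc(Cl)c(Cn3cc(CN4c5ccccc5C(C)=CC4(C)C)nn3)cc2c1` which has methoxy in place of methyl on an aromatic carbon and otherwise matches compound 2. Among the measured compounds shown here, no step between measured compounds shows what such a swap does, so the expectation is no shift beyond the scatter in this assay in either direction. The estimated change is a 1.0-fold higher number from compound 2 to compound 3 (0.01 log units; within the scatter) and it rests only on the closeness of compound 1 at 30900 nM and compound 2 at 29400 nM in the same test. Compound 3 is estimated at 30000 nM with an expected range from 14000 nM to 60000 nM on repeated measurement.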

Compound 3, half-maximal inhibitory concentration: 33400 nM
Compound 3: the middle estimate sits 1.1-fold (0.05 log units) below what was measured; the range from low to high includes it.
By their numbers in this assay, from the lowest: compounds 2, 1 and 3 (each within the scatter of the next).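

In this assay, among the compounds shown here, the first direct comparison at this aromatic carbon, methoxy in place of methyl, gives a 1.1-fold higher number from compound 2 to compound 3 (0.06 log units; within the scatter), so the two groups cannot be told apart here. At a different aromatic carbon, hydrogen in place of methoxy gives a 1.1-fold higher number from compound 1 to compound 3 (0.03 log units; within the scatter), which also lies within the scatter, so neither single change separates its pair of compounds. No independent evidence is available to explain these results.

Only methyl and methoxy are shown at the first position, and only methoxy and hydrogen at the second, so these steps cover a narrow set of groups. On these data alone, whether an amine or a carboxylic acid at either carbon would move the number beyond the scatter remains open.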